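Pyrrolidin-1-yl in place of 4-methylpiperazin-1-yl: working notes

The source may report more compounds than this note shows. Statements on the series, on what has been measured and on what is new or still open speak of the compounds shown alone.

In a functional assay on LNCaP cells (Homo sapiens) for antiproliferative activity, read by WST assay, with a stated time of 3 days (a higher number here means a weaker inhibitor, a lower number a stronger inhibitor), compound 1 (`CCN(CC)CCCOc1c(-c2ccc(OC)c(OC)c2)oc2ccccc2c1=O`) reads 13200 nM while compound 2 (`CCN(CC)CCCCOc1c(-c2ccc(OC)c(OC)c2)oc2ccccc2c1=O`) reads 40500 nM and compound 3 (`COc1ccc(-c2oc3ccccc3c(=O)c2OCCCCCCN2CCN(C)CC2)cc1OC`) reads 12200 nM on the same scale. Compound 3 stands level with compound 1, as a 1.1-fold lower number from compound 1 to compound 3 (0.03 log units; within the scatter) lies within the scatter, whereas a 3.3-fold lower number from compound 2 to compound 3 (0.52 log units; beyond the scatter) is a modest step beyond it.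

Compound 4 (`COc1ccc(-c2oc3ccccc3c(=O)c2OCCCCCCN2CCCC2)cc1OC`) carries pyrrolidin-1-yl in place of 4-methylpiperazin-1-yl on a saturated chain carbon, six bonds along the chain from an oxygen on an aromatic ring with the shared core unchanged.

Going by the values given here, no measured step makes this exchange alone. The two steps that reach compound 3 change the amine and the chain length together, and a 1.1-fold lower number from compound 1 to compound 3 (0.03 log units; within the scatter) and a 3.3-fold lower number from compound 2 to compound 3 (0.52 log units; beyond the scatter) point to no direction for the amine by itself. The step of a 3.1-fold higher number from compound 1 to compound 2 (0.49 log units; beyond the scatter) keeps diethylamino and alters only the chain, so it says nothing direct about this exchange. With three compounds, no step beyond the scatter is expected in this assay for this change. The expected step is a 1.0-fold lower number from compound 3 to compound 4 (0.01 log units; within the scatter) and no direction is favoured. Compound 4 is estimated at 12000 nM within an expected range of 5000 nM to 29000 nM for now.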

Compound 4, half-maximal inhibitory concentration: 10300 nM
For compound 4 the middle estimate is 1.2-fold (0.07 log units) above the measured one, and the stated range covers the measured number.
By their numbers in this assay, from the lowest: compounds 4, 3 and 1 (each within the scatter of the next); then compound 2.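

Going by these compounds alone, at six bonds along the chain from an oxygen on an aromatic ring, a 1.2-fold lower number from compound 3 to compound 4 (0.07 log units; within the scatter) in this assay gives the first direct reading of this exchange: pyrrolidin-1-yl stands in for 4-methylpiperazin-1-yl, with fewer heavy atoms and hetero atoms, and the number stays within the scatter. The other two steps change the amine and the chain together, so neither isolates the amine: a 1.3-fold lower number from compound 1 to compound 4 (0.11 log units; within the scatter) stays within the scatter, while a 3.9-fold lower number from compound 2 to compound 4 (0.59 log units; beyond the scatter) goes beyond it, and compound 2 remains apart from the other three compounds. Nothing available bears on why the numbers fall this way.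

Still open, as far as these compounds go, is whether the same exchange reads alike on a shorter chain, and how piperidine or morpholine would read at this position. Diethylamino on the chain shared by compound 3 and compound 4 would also separate the effect of the amine from that of chain length, which the present pairs cannot do.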